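This account rests on a few compounds, and the source may have more. Where it says the series, first, only, none or still open, it means among the compounds named here.

Measured compounds:
compound 1, `CCOC(=O)CNC(C)(C)CC(=O)N[C@@H]1CCc2ccccc2N(Cc2ccc(-c3ccccc3-c3nn[nH]n3)cc2)C1=O` — 56 nM
compound 2, `CC(C)(CC(=O)N[C@@H]1CCc2ccccc2N(Cc2ccc(-c3ccccc3-c3nn[nH]n3)cc2)C1=O)NC[C@H](O)[C@@H](O)CO` — 40 nM
compound 3, `CC(C)(N)C(=O)N[C@@H]1CCc2ccccc2N(Cc2ccc(-c3ccccc3-c3nn[nH]n3)cc2)C1=O` — 30 nM

In a functional assay (Pituitary gland cell) with Rattus norvegicus as the target (a lower number here means that less compound is needed, a higher number that more compound is needed for the effect), compound 1 gives 56 nM, the highest of the three numbers, yet its gaps to both neighbours lie within the scatter: a 1.4-fold lower number from compound 1 to compound 2 (0.15 log units; within the scatter) and a 1.9-fold lower number from compound 1 to compound 3 (0.27 log units; within the scatter). The three values are therefore not distinguishable, and no order among compound 1, compound 2 and compound 3 can be read from them.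

Compound 4, `C[C@@H](O)CNC(C)(C)C(=O)N[C@@H]1CCc2ccccc2N(Cc2ccc(-c3ccccc3-c3nn[nH]n3)cc2)C1=O`, has not yet been measured in this assay. Its change from compound 1: 1-((2-hydroxypropyl)amino)-1-methylethyl in place of 2-(((ethoxycarbonyl)methyl)amino)-2-methylpropyl on a carbonyl carbon. Among the compounds with values here, two measured steps bear on this change. a 1.4-fold lower number from compound 1 to compound 2 (0.15 log units; within the scatter) exchanges the ethoxycarbonyl on a saturated chain carbon bound to an amine nitrogen for a hydroxylated chain, and a 1.9-fold lower number from compound 1 to compound 3 (0.27 log units; within the scatter) shortens the group on the carbonyl carbon to 1-amino-1-methylethyl; the entering group of compound 4 combines a shortened chain with a hydroxylated substituent on the amine nitrogen. a 1.3-fold lower number from compound 2 to compound 3 (0.12 log units; within the scatter) likewise stays within the scatter. Since every step across this part of the shared core was within the scatter, no step beyond the scatter is expected from compound 1 to compound 4 in this assay, and the expected step is a 1.4-fold lower number from compound 1 to compound 4 (0.15 log units; within the scatter). Compound 4 is estimated at 40 nM, with a range from 20 nM to 85 nM.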

Compound 4, concentration for half-maximal effect: 300 nM
Estimate against measurement, compound 4: 7.5-fold (0.88 log units) below, outside the stated range (above it).
By their numbers in this assay, from the lowest: compounds 3, 2 and 1 (each within the scatter of the next); then compound 4.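

In this assay the amine nitrogen of compound 3 proves sensitive to substitution: 2-hydroxypropyl in place of hydrogen gives a 10-fold higher number from compound 3 to compound 4 (1.00 log units; beyond the scatter) as the step, the first one in this set beyond the scatter. Substitution on that nitrogen does not always go with a higher number, since compound 1 and compound 2 also carry a substituent there and stay within the scatter of compound 3, while a 5.4-fold higher number from compound 1 to compound 4 (0.73 log units; beyond the scatter) and a 7.5-fold higher number from compound 2 to compound 4 (0.88 log units; beyond the scatter) set the 1-((2-hydroxypropyl)amino)-1-methylethyl group on the carbonyl carbon apart from both longer groups. Nothing available explains why this group stands apart from the others at this position.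

Still open, going by these compounds, is whether the higher number follows the hydroxyl or the substituent as a whole, which a plain ethyl group or a 2-methoxypropyl group on the same amine nitrogen would separate. Also open, on these data alone, is whether 2-hydroxypropyl behaves the same way on the longer chain of compound 1 and compound 2, and whether the opposite configuration at its stereocentre gives a different number.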